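A few compounds are considered here, and "the series" means these few. Any claim that something is new, unique, unknown or untested is made for them only; others in the source may bear on it.

Measured compounds in a functional assay on HCT-15 cells (Homo sapiens) for cytotoxicity, read by sulforhodamine B assay, with a stated time of 72 h; on this read-out higher numbers stand for weaker inhibition of growth and lower numbers for stronger inhibition of growth:

compound 1, `O=C(Nc1ccccc1O)C1CCc2ccccc2N1C(=O)c1ccc(Cl)cc1`, 20200 nM
compound 2, `CCCCCCCCC(=O)N1c2ccccc2CCC1C(=O)Nc1ccccc1C(F)(F)F`, 7700 nM
compound 3, `O=C(Nc1ccccc1C(F)(F)F)C1CCc2ccccc2N1C(=O)c1ccc(Cl)cc1`, 839 nM

Compound 3 and compound 1 share a core and differ in one place:

hydroxy in place of trifluoromethyl on an aromatic carbon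

This change gives a 24-fold higher number from compound 3 to compound 1 (1.38 log units; beyond the scatter), so within this pair the hydroxy analogue shows the weaker growth inhibition by a wide margin.

Compound 2 differs from compound 3 only at the carbonyl carbon on the ring nitrogen:

octyl in place of 4-chlorophenyl on a carbonyl carbon

Here a 9.2-fold lower number from compound 2 to compound 3 (0.96 log units; beyond the scatter), so the 4-chlorophenyl core gives the stronger inhibition of the two cores. In this assay compound 2 stands second highest of the three numbers measured.

Compound 4, `CCCCCCCCC(=O)N1c2ccccc2CCC1C(=O)Nc1ccccc1O`, has not yet been measured in this assay. It relates to compound 2 as compound 1 relates to compound 3:

hydroxy in place of trifluoromethyl on an aromatic carbon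

The two descriptions of the place agree word for word, so this is the same change as before, now made on the octyl core. Among the measured compounds shown here, nothing measured tells whether the octyl core carries the change in the same way as the 4-chlorophenyl core; only one pair shows it. The expectation for compound 4 is a weakening of growth inhibition, and the step expected from compound 2 is a 12-fold higher number from compound 2 to compound 4 (1.07 log units; beyond the scatter), set beside a 24-fold higher number from compound 3 to compound 1 (1.38 log units; beyond the scatter) and resting on that earlier pair, with some allowance for the step not carrying over in full. For compound 4 the estimate in this assay is 90000 nM, expected to lie between 30000 nM and 200000 nM.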

Compound 4, concentration for 50% growth inhibition: 38400 nM
Compound 4: middle estimate off by 2.3-fold (0.37 log units), on the high side; the range from low to high includes it.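

In this assay the change to hydroxy from trifluoromethyl moves the number the same way on the octyl core, a 5.0-fold higher number from compound 2 to compound 4 (0.70 log units; beyond the scatter), so the direction carries from one core to the other, but the size does not: the same change on two cores in this assay, a 24-fold higher number (1.38 log units; beyond the scatter) from compound 3 to compound 1 and a 5.0-fold higher number (0.70 log units; beyond the scatter) from compound 2 to compound 4, 4.8-fold (0.68 log units) apart, beyond the scatter of two such steps

Read the other way round, the change to octyl from 4-chlorophenyl gives a 1.9-fold higher number from compound 1 to compound 4 (0.28 log units; within the scatter) when hydroxy is present, which leaves the two hydroxy compounds indistinguishable, and it does not match the step seen with trifluoromethyl present: the same change on two cores in this assay, a 9.2-fold lower number (0.96 log units; beyond the scatter) from compound 2 to compound 3 and a 1.9-fold lower number (0.28 log units; within the scatter) from compound 4 to compound 1, 4.8-fold (0.68 log units) apart, beyond the scatter of two such steps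

Among the compounds shown here, the two changes therefore do not add independently across these four compounds, and a step measured on one core gave the sign but not the size on the other; with only two cores and two groups at each place, this sets no rule for further cores and gives no explanation for the difference in size.

The compounds shown leave open whether a methoxy group, a chlorine or an amine in place of the trifluoromethyl would also give steps that differ between the two cores. They also leave open whether a chain shorter than octyl, or a phenyl without the chlorine, on the carbonyl carbon would follow compound 2 and compound 4 or compound 3 and compound 1.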